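The source may report more compounds than this note shows. Statements on the series, on what has been measured and on what is new or still open speak of the compounds shown alone.

In a functional assay on MCF7 cells (Homo sapiens) for inhibition, read by MTT assay, with a stated time of 48 h (on this read-out higher numbers stand for weaker inhibition and lower numbers for stronger inhibition), compound 1 `O=C1N/C(=N\Cc2ccc(C(F)(F)F)cc2)S/C1=C1/CCNC(=O)c2[nH]ccc21` gives > 100000 nM as a limit of the assay and not as a number. Compound 2 `O=C1N/C(=N\Cc2ccc(Cl)cc2)S/C1=C1/CCNC(=O)c2[nH]ccc21` gives > 100000 nM as a limit too, so it has no exact position on the scale. What has been measured so far comes down to the limit of > 100000 nM in this assay, at which 2 of the 2 values shown sit, and nothing more.

Compound 3 `CC(C)(C)c1ccc(C/N=C2\NC(=O)/C(=C3\CCNC(=O)c4[nH]ccc43)S2)cc1` differs from compound 2 by tert-butyl in place of chloro on an aromatic carbon in that tert-butyl stands in place of chloro on an aromatic carbon, para to a large group. Within the data shown here, the one measured step that bears on this change is a step that the two limits leave unreadable from compound 1 to compound 2 and offers no size to carry over. It gives no direction either, so no step beyond the scatter is expected in this assay for compound 3. With compound 2 at > 100000 nM as a limit, compound 3 is expected to remain at or close to that same limit. The estimated change is a number no higher from compound 2 to compound 3 (the limit leaves the size open) on this reasoning. For compound 3 the estimate is 100000 nM with 30000 nM to 200000 nM as the expected range.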

Compound 3, half-maximal inhibitory concentration: 18900 nM
Estimate against measurement, compound 3: 5.3-fold (0.72 log units) above; measured number outside the range, below it.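

In this assay, the place on the six-membered aromatic ring para to a large group turns out to be able to bring the read-out off the limit: tert-butyl in place of chloro gives an at least 5.2-fold lower number from compound 2 to compound 3 (0.72 log units; beyond the scatter), and tert-butyl in place of trifluoromethyl gives an at least 5.2-fold lower number from compound 1 to compound 3 (0.72 log units; beyond the scatter). Both steps have an open size on one side, and the step from compound 1 to compound 2 cannot be read, so chloro and trifluoromethyl cannot be ordered against each other. Compound 3 is the only one of the three with an exact position on the scale, so the gain rests on a single number set against limits: the limit of > 100000 nM in this assay, at which 2 of the 3 values shown sit.

The compounds shown leave open which feature of tert-butyl matters, and whether a smaller or larger carbon group at this place, such as methyl or a longer alkyl chain, would keep the gain. They also leave open how an amine or a carboxylic acid at the same place would read out, and how far the true steps reach.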